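The source may hold more compounds than are shown below. What is called first, only, known or untested is meant among the compounds shown, and "the series" means these compounds.

Measured compounds:
- compound 1 `O=C(Nc1ccc(Cl)cc1)C(=O)N1CCC(c2ccnc3ccc(F)cc23)CC1`: 9 mL.min-1.g-1
- compound 2 `N#Cc1ccc(NC(=O)C(=O)N2CCC(c3ccnc4ccc(F)cc34)CC2)cc1`: 11 mL.min-1.g-1
- compound 3 `O=C(Nc1ccc(Cl)cc1)C(=O)N1CCC(c2ccnc3ccc(Cl)cc23)CC1`: 11 mL.min-1.g-1

In an ADME assay on microsomes from liver (Homo sapiens) for metabolic stability (a higher number here means faster removal of the compound, a lower number slower removal), the three measured compounds lie close together. Compound 1 is within the scatter of both compound 2 and compound 3, so it holds no clearly separate place among them.

The step to follow leads to compound 4 `O=C(Nc1ccc(Cl)cc1)C(=O)N1CC[C@H](c2ccnc3ccc(F)cc23)[C@@H](O)C1`, which has not yet been measured. The structural change from compound 1 is hydroxy in place of hydrogen on a saturated ring carbon.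

Two measured steps offer some guidance, though only indirectly. Cyano in place of chloro on an aromatic carbon gave a 1.2-fold higher number from compound 1 to compound 2 (0.09 log units; within the scatter), and chloro in place of fluoro on an aromatic carbon gave a 1.2-fold higher number from compound 1 to compound 3 (0.09 log units; within the scatter). Both steps are within the scatter, but both were made on aromatic carbons, so neither tests a change on a saturated ring carbon. Within the data shown here, the data contain no direct example of adding hydroxy.

Going by these small steps alone, no step beyond the scatter is expected in this assay, in either direction, although the range must stay wide. For compound 4, the estimated value is 8 mL.min-1.g-1, with an expected range from 4 mL.min-1.g-1 to 16 mL.min-1.g-1. This estimate means an expected 1.1-fold lower number from compound 1 to compound 4 (0.05 log units; within the scatter).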

Compound 4, intrinsic clearance in microsomes: 4 mL.min-1.g-1
Compound 4: middle estimate off by 2.0-fold (0.30 log units), on the high side, and the stated range covers the measured number.
By their numbers in this assay, from the lowest: compound 4; then compounds 1, 2 and 3 (each within the scatter of the next).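

In this assay, among these compounds, hydroxy in place of hydrogen on a saturated ring carbon gives a 2.3-fold lower number from compound 1 to compound 4 (0.35 log units; beyond the scatter) and so is the only step in this small set that lies beyond the scatter. The two earlier steps were made on aromatic carbons and stayed within the scatter, so they said nothing about the saturated ring; this result shows that a single added hydroxy, placed two ring bonds from the ring nitrogen and next to the ring atom that bears a large group, can move the number downward. Nothing available here explains why the number moved, so the step stands only as an observation.

From the compounds shown here alone, whether a methoxy group, a fluoro group or an amine on this same ring carbon would lower the number as well remains open, as does the effect of the opposite spatial arrangement of the hydroxy. Going by these compounds, it is also open whether the same hydroxy step would give a similar drop on compound 2 or compound 3, since one step on one compound cannot establish a general pattern.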